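The compounds below may be only part of what the source reports. "The series", "measured", "known", "first", "only" and "open" are said of these compounds alone.

Measured compounds in a functional assay on Huh-7 cells (Homo sapiens) for cytotoxicity, read by sulforhodamine B assay, with a stated time of 72 h; a lower number here means a stronger inhibitor, a higher number a weaker inhibitor:
- compound 1, `FC(F)(F)c1ccc(N2CCN(c3ncnc4[nH]cnc34)CC2)cc1`, gives 3200 nM
- compound 2, `C1=CC(CCNc2ncnc3[nH]cnc23)CCC1`, gives 14200 nM
- compound 3, `Cc1ccc(S(=O)(=O)n2cnc3c(NCc4ccc(Cl)cc4Cl)ncnc32)cc1`, gives 26900 nM

Among these three, compound 1 has the lowest number in this assay, and its steps to compound 2 and to compound 3 both lie beyond the scatter, so compound 1 is the strongest inhibitor of the set. The three compounds share a core but differ at several places at once, so no single change can be read from their values.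

Compound 4, `FC(F)(F)c1ccc(N2CCN(c3ncnc4c3ncn4C3CCCC3)CC2)cc1`, is not yet measured. It differs from compound 1 in one place: cyclopentyl in place of hydrogen on an aromatic nitrogen. Nothing measured here shows what such a change does on its own, since compound 3 carries a different group on that ring nitrogen together with a different amine.

The expectation is a step from compound 1 to compound 4 of a 1.3-fold lower number from compound 1 to compound 4 (0.11 log units; within the scatter), within the scatter or a little toward a stronger inhibitor. Compound 4 is estimated at 2500 nM in this assay, with a range from 800 nM to 8000 nM.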

Compound 4, half-maximal inhibitory concentration: 200 nM
Beside the measured number, compound 4's estimate is 13-fold (1.10 log units) above it, and the stated range ends above it.
By their numbers in this assay, from the lowest: compound 4; then compound 1; then compounds 2 and 3 (each within the scatter of the next).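

In this assay, cyclopentyl in place of hydrogen on an aromatic nitrogen gives a 16-fold lower number from compound 1 to compound 4 (1.20 log units; beyond the scatter), a large move toward a stronger inhibitor with the rest of the molecule unchanged. Among these compounds, the earlier compounds differ at several places at once, so this pair is the first to show that this ring nitrogen alone can shift the number so far, and that the hydrogen there is not needed for activity in these cells. Nothing available explains why the number falls by this much.

The compounds shown leave open whether the gain needs a ring of carbon, or whether a methyl group, a longer chain such as pentyl, or a larger cyclohexyl ring would do the same. They also do not show whether cyclopentyl brings a similar gain on the core of compound 2, which carries a different amine.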